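Ring Side Chain Variation and Cytotoxicity in HEL Cells

The source may hold more compounds than are shown below. What is called first, only, known or untested is meant among the compounds shown, and "the series" means these compounds.

Measured compounds:
Compound 1, `CCC1(Cc2ccccc2)OS(=O)(=O)C=C1OC`, in an ADME assay on HEL cells (Homo sapiens) for cytotoxicity, with a stated time of 3 days; on this read-out higher numbers stand for lower toxicity in this test and lower numbers for higher toxicity in this test: > 200000 nM (a limit of the assay, not a number).
Compound 2, `CC(C)CC1(Cc2ccccc2)OS(=O)(=O)C=C1OCc1ccccc1`: 102000 nM
Compound 3, `CC(C)C1(Cc2ccccc2)OS(=O)(=O)C=C1OCc1ccccc1`: 200000 nM

Three compounds share a core and differ in the chain on a saturated ring carbon. Compound 1 reaches only a limit of the assay (the limit of > 200000 nM in this assay, at which 1 of the 3 values shown sits). Among the two numbers, compound 3 has the highest, and its nearest neighbour is compound 2 a 2.0-fold higher number from compound 2 to compound 3 (0.29 log units; within the scatter). So the two numbers do not separate in this assay.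

Compound 4, `CCCC1(Cc2ccccc2)OS(=O)(=O)C=C1OCc1ccccc1`, is not yet measured. It differs from compound 3 in one place (propyl in place of isopropyl on a saturated ring carbon). For the measured compounds named here, the only measured step that touches the same position is the one between compound 2 and compound 3, in which a branched chain of a different length was exchanged and the result stayed within the scatter. A swap of one three-carbon chain for another at the same place is therefore expected to move the number no further than the scatter, in no particular direction.

Compound 4 is thus estimated at 150000 nM, with a range from 70000 nM to 300000 nM. This estimate means a step of a 1.3-fold lower number from compound 3 to compound 4 (0.12 log units; within the scatter), and a limit rather than a number is a real possibility.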

Compound 4, half-maximal cytotoxic concentration: 200000 nM
Beside the measured number, compound 4's estimate is 1.3-fold (0.12 log units) below it, and the stated range covers the measured number.
By their numbers in this assay, from the lowest: compounds 2, 3 and 4 (each within the scatter of the next).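

In this assay, the earlier pair changed chain length and branching together, whereas here the atoms stay the same and only the way they are joined differs, giving no change at the digits printed from compound 3 to compound 4 (within the scatter). Trimming the isobutyl chain of compound 2 down to the propyl chain of compound 4 gives a 2.0-fold higher number from compound 2 to compound 4 (0.29 log units; within the scatter), so isobutyl, isopropyl and propyl on this saturated ring carbon are not separated by this assay. The figure shared by compound 3 and compound 4 is also the figure at which the limit of the test stands, so any spread at this position on that side could not be read here: the limit of > 200000 nM in this assay, at which 1 of the 4 values shown sits.

As far as these compounds go, all the chains compared at this ring carbon are built only of carbon and hydrogen, so what an amine, a carboxylic acid or a much longer chain such as octyl would do there remains open. From the compounds shown here alone, these readings also speak only to this assay, and how the same chains behave on any other read-out is unknown.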